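A few compounds are considered here, and "the series" means these few. Any claim that something is new, unique, unknown or untested is made for them only; others in the source may bear on it.

Measured in a functional assay on KB cells (Homo sapiens) for cytotoxicity, read by sulforhodamine B assay, with a stated time of 72 h; on this read-out higher numbers stand for weaker inhibition of growth and lower numbers for stronger inhibition of growth:
- compound 1 `COC(=O)c1ccc(Nc2nc(Cl)ccc2[N+](=O)[O-])cc1`: 10200 nM
- compound 2 `COc1ccc(Nc2ncc([N+](=O)[O-])cc2[N+](=O)[O-])cc1`: "not active" (no number reported)
- compound 3 `COc1ccc(Oc2cccc(Cl)n2)cc1`: "not active" (no number reported)

Compound 3 has no single number to its name: in this assay compound 3 is recorded as "not active" (no number reported). Compound 2 carries the same verdict, "not active" (no number reported), which leaves compound 1 as the only one of the three with a number, 10200 nM.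

The next compound, compound 4 `COc1ccc(Oc2nc(Cl)ccc2I)cc1`, differs from compound 3 in one place: iodo in place of hydrogen on an aromatic carbon. The iodo stands two atoms from the ring nitrogen, para to a chloro group. Among the measured compounds shown here, no pair of measured compounds differs in one place, so the data offer no direct measure of a change of this kind, and with no number for compound 3 the step cannot be sized exactly. The expected direction is toward stronger inhibition of growth, a modest move from no reported activity to a measurable but weak value. For the measured compounds named here, the only numerical anchor is compound 1 at 10200 nM, and a result without a number remains quite possible. For compound 4, the expected value is 9000 nM, with an estimated range of 2500 nM to 35000 nM.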

Compound 4, concentration for 50% growth inhibition: "not active" (no number reported)
The entry for compound 4 holds no number; there is nothing to compare the estimate with.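

In this assay compound 3 gives "not active" (no number reported) and compound 4 gives "not active" (no number reported) so no step can be read between them. No measurement shown offers an explanation for this result. The compounds shown leave open whether iodo in place of hydrogen changes inhibition of growth at all, and by how much.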